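Acylation of a pyrazoline nitrogen: expected gain in cell inhibition

The source may report more compounds than this note shows. Statements on the series, on what has been measured and on what is new or still open speak of the compounds shown alone.

Measured so far:
compound 1 `CN1CCN(c2ccc(C3=NNC(c4ccc(N(C)C)cc4)C3)cc2)CC1`, 11.4%
compound 2 `CN(C)c1ccc(C2CC(c3ccc(-n4cncn4)cc3)=NN2)cc1`, 7%
compound 3 `CN1CCN(c2ccc(C3=NN(S(=O)(=O)c4ccc(C#N)cc4)C(c4ccc(N(C)C)cc4)C3)cc2)CC1`, 99.8%

In a functional assay on MDA-MB-231 cells (Homo sapiens) for inhibition, read by sulforhodamine B assay, tested at 10 uM (a higher number here means more inhibition at the concentration tested (going by the name of the read-out), a lower number less inhibition), compound 2 gives the lowest of the three numbers. Its nearest neighbour is compound 1, and the difference a number 4.4 percentage points lower from compound 1 to compound 2 (within the scatter) lies within the scatter, so the two cannot be told apart. Among the compounds with values here, compound 3 stands far away from both, and the one measured step that reaches it, a number 88.4 percentage points higher from compound 1 to compound 3 (beyond the scatter), is large and beyond the scatter.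

Compound 4 `CN(C)c1ccc(C2CC(c3ccc(-n4cncn4)cc3)=NN2C(=O)c2ccc(C(F)(F)F)cc2)cc1` is not yet measured. It differs from compound 2 by (4-(trifluoromethyl)phenyl)carbonyl in place of hydrogen on an amine nitrogen in a ring. This is the same kind of change that separates compound 3 from compound 1: a hydrogen on the ring amine nitrogen is replaced by an aromatic substituent carrying a double-bonded oxygen, although here it is a carbonyl rather than a sulfonyl. Within the data shown here, that single bearing step was large and upward, so a large upward step is expected for compound 4 as well, a number 68 percentage points higher from compound 2 to compound 4 (beyond the scatter), with a wide range because only one such step has been seen and the connecting group is not identical. Compound 4 is therefore estimated at 75%, between 35% and 99%.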

Compound 4, a percentage reported as inhibition, at one concentration (the size of the read-out at that concentration, not a potency): 16.7%
Compound 4: the middle estimate sits 58.3 percentage points above what was measured, outside the stated range (below it).
By their numbers in this assay, from the lowest: compounds 2, 1 and 4 (each within the scatter of the next); then compound 3.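

In this assay the entry of (4-(trifluoromethyl)phenyl)carbonyl on the amine nitrogen in the ring comes to a number 9.7 percentage points higher from compound 2 to compound 4 (within the scatter) and so leaves no measurable mark on this background. An aromatic group attached through a carbonyl at this nitrogen is therefore not enough by itself to give a high number in this series. The large step of a number 88.4 percentage points higher from compound 1 to compound 3 (beyond the scatter) now stands as the result of one pairing, (4-cyanophenyl)sulfonyl on a compound carrying 4-methylpiperazin-1-yl, and cannot be read as a general effect of filling this position. Nothing available here accounts for the difference between the two steps.

The two steps differ both in the group that enters and in the group carried on the other side of the molecule, so the compounds shown cannot separate the role of the sulfonyl link, the nitrile or trifluoromethyl ending, and the 4-methylpiperazin-1-yl or 1H-1,2,4-triazol-1-yl group. Also open, on these data alone, is how a small acetyl group on the same nitrogen would read in this assay, and whether (4-cyanophenyl)sulfonyl keeps its large step on the triazole-bearing compound 2.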